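This account rests on a few compounds, and the source may have more. Where it says the series, first, only, none or still open, it means among the compounds named here.

Compound 1 `Fc1ccc(C2CC(c3ccc(Cl)s3)=NN2c2nc(-c3ccccc3)cs2)cc1` is one of two compounds tested in an ADME assay on NIH3T3 cells (Mus musculus) for cytotoxicity, read by XTT assay, with a stated time of 24 h; on this read-out higher numbers stand for weaker inhibition and lower numbers for stronger inhibition. In this assay compound 1 gives only > 500 ug/mL, which is a limit of the assay rather than a number. The second compound, compound 2 `COc1ccc(-c2csc(N3N=C(c4ccc(C)s4)CC3c3ccc(F)cc3)n2)cc1`, gives 147 ug/mL in this assay. Compound 1 thus stands at the limit of > 500 ug/mL in this assay, at which 1 of the 2 values shown sits. Compound 3 `O=[N+]([O-])c1ccc(-c2csc(N3N=C(c4ccc(Cl)s4)CC3c3ccc(F)cc3)n2)cc1` differs from compound 1 by nitro in place of hydrogen on an aromatic carbon. No measured step of this kind exists among these compounds, so the expectation rests on compound 1 alone. For compound 3 a step of an at least 1.5-fold lower number from compound 1 to compound 3 (0.19 log units; that floor lies within the scatter) is expected, likely within the scatter and of uncertain direction. Compound 3 is therefore estimated at 320 ug/mL, with a range from 100 ug/mL to 600 ug/mL.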

Compound 3, half-maximal inhibitory concentration: > 500 ug/mL
Compound 3 gave a limit, no number; the forecaster's own chance of this, stated with the estimate: 40%; at least 1.5-fold (0.19 log units) between middle value and limit.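

In this assay compound 3 gives > 500 ug/mL, a limit and not a number. Compound 1 also sits at a limit, so no step can be read between these two compounds. On these data alone, whether nitro in place of hydrogen changes the value at all stays open.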